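Working notes: amide-side replacement toward compound 3

A few compounds are considered here, and "the series" means these few. Any claim that something is new, unique, unknown or untested is made for them only; others in the source may bear on it.

Compound 1 `CCC1CCCN(C(=O)CN2CN(c3ccccc3)C3(CCN(C(=O)c4ccc(C5CCCCC5)cc4)CC3)C2=O)C1` gives 2600 nM in an assay on HEK293 cells for displacement of a labelled ligand from NPC1-like intracellular cholesterol transporter 1 (Homo sapiens) (a lower number here means a stronger inhibitor, a higher number a weaker inhibitor), the lowest of the two numbers shown, though its only neighbour, compound 2 `CCC1CCCN(C(=O)CN2CN(c3ccccc3)C3(CCN(C(=O)c4ccc(C(C)(C)C)cc4)CC3)C2=O)C1` at 3900 nM, lies within scatter: a 1.5-fold higher number from compound 1 to compound 2 (0.18 log units; within the scatter). Compound 3 `O=C(CN1CN(c2ccccc2)C2(CCN(C(=O)c3ccc(C4CCCCC4)cc3)CC2)C1=O)NCO` differs from compound 1 by (hydroxymethyl)amino in place of 3-ethylpiperidin-1-yl on a carbonyl carbon. Within the data shown here, the one measured step concerns a group on an aromatic carbon, not the carbonyl carbon changed here, so no measured step bears on this change and the direction is open. The estimate is therefore wide: a 1.9-fold higher number from compound 1 to compound 3 (0.28 log units; within the scatter) is expected. Compound 3 is estimated at 5000 nM, between 1300 nM and 20000 nM.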

Compound 3, half-maximal inhibitory concentration: 8300 nM
Compound 3: the middle estimate sits 1.7-fold (0.22 log units) below what was measured, within the range that was stated.
By their numbers in this assay, from the lowest: compounds 1 and 2 (each within the scatter of the next); then compound 3.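

Among these compounds, on the carbonyl carbon, (hydroxymethyl)amino in place of 3-ethylpiperidin-1-yl gives the first step beyond the scatter: in this assay there is a 3.2-fold higher number from compound 1 to compound 3 (0.50 log units; beyond the scatter). This position therefore registers a change, though a modest one, even with the ring gone and fewer heavy atoms in the entering group. No available data account for this step. Going by these compounds, whether the ring, the ethyl group or the hydroxymethyl group drives the shift remains open; an unsubstituted piperidine or a dimethylamino group on the same carbonyl carbon would help separate these.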